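Chloro substitution on the benzyl ring of the indole series

The compounds below may be only part of what the source reports. "The series", "measured", "known", "first", "only" and "open" are said of these compounds alone.

Compound 2 `CCN(CC)Cc1ccc2nc(NC(=O)N/N=C/c3cn(Cc4ccc(Cl)cc4)c4ccccc34)sc2c1` gives 370 nM in a functional assay on NCI-H460 cells (Homo sapiens) for cytotoxicity, read by MTT assay, with a stated time of 72 h (a higher number here means a weaker inhibitor, a lower number a stronger inhibitor), and compound 1 `CCN(CC)Cc1ccc2nc(NC(=O)N/N=C/c3cn(Cc4ccc(Cl)cc4Cl)c4ccccc34)sc2c1` gives 1080 nM. Between them lies (chloro in place of hydrogen on an aromatic carbon), which made a 2.9-fold higher number from compound 2 to compound 1 (0.47 log units; beyond the scatter). Compound 3 `CN(C)Cc1ccc2nc(NC(=O)N/N=C/c3cn(Cc4ccccc4)c4ccccc34)sc2c1` differs from compound 2 in more than one place, and that difference is not broken down here. In this assay compound 3 gives 400 nM. Compound 3 and compound 2 lie within the scatter of each other. Compound 4 `CN(C)Cc1ccc2nc(NC(=O)N/N=C/c3cn(Cc4ccc(Cl)cc4)c4ccccc34)sc2c1` is not yet measured; it differs from compound 3 by chloro in place of hydrogen on an aromatic carbon. This is the same kind of change as from compound 2 to compound 1, but the place differs: here para to a large group, there ortho to a large group and meta to a chloro group. The expected step is a 1.3-fold higher number from compound 3 to compound 4 (0.10 log units; within the scatter), read beside a 2.9-fold higher number from compound 2 to compound 1 (0.47 log units; beyond the scatter) with caution, since the change here starts from a different value. Compound 2 gives 370 nM, whereas compound 3 gives 400 nM. Compound 4 is estimated at 500 nM, between 200 nM and 1300 nM.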

Compound 4, half-maximal inhibitory concentration: 290 nM
Beside the measured number, compound 4's estimate is 1.7-fold (0.24 log units) above it; measured number inside the range.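

In this assay, chloro in place of hydrogen does not carry over from one core to the other as a single step: the same change on two cores in this assay, a 2.9-fold higher number (0.47 log units; beyond the scatter) from compound 2 to compound 1 and a 1.4-fold lower number (0.14 log units; within the scatter) from compound 3 to compound 4, 4.0-fold (0.60 log units) apart, beyond the scatter of two such steps

Benzyl to 4-chlorobenzyl gives a 1.4-fold lower number from compound 3 to compound 4 (0.14 log units; within the scatter), and dimethylamino in place of diethylamino gives a 1.3-fold lower number from compound 2 to compound 4 (0.11 log units; within the scatter); neither change separates the compounds it joins. The two chloro steps also differ in their place on the ring, with the chloro of compound 4 para to a large group, so the gap does not show whether the amine or the place accounts for it, and one pair per core sets no rule.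

Still open, on these data alone, is whether other groups on the benzyl ring, such as fluoro or methoxy, follow chloro. Also open, as far as these compounds go, is how a cyclic amine such as morpholine compares with dimethylamino.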